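The compounds below may be only part of what the source reports. "The series", "measured", "known", "first", "only" and "open" are said of these compounds alone.

The compounds here share one core, seen in compound 1 (`O=C(Nc1ccc2c(c1)B(O)OC2)c1ccccc1`). In a functional assay on PBMC cells (Homo sapiens) for inhibition, read by HTRF, with stated times of 15 min and 24 h (on this read-out higher numbers stand for weaker inhibition and lower numbers for stronger inhibition), compound 1 gives > 100000 nM, which is a limit of the assay and not a number. Compound 2 (`O=C(Nc1ccc2c(c1)B(O)OC2)c1ccccc1F`) gives > 10000 nM in this assay, also a limit. Compound 3 (`O=C(Nc1ccc2c(c1)B(O)OC2)c1ccccc1Cl`) gives > 100000 nM in this assay, likewise a limit, so it offers no number to start from.

Compound 4 (`O=C(Nc1ccc2c(c1)B(O)OC2)c1c(F)cccc1Cl`) keeps the chloro group of compound 3 and changes one place: fluoro in place of hydrogen on an aromatic carbon. This is fluoro in place of hydrogen on an aromatic carbon, ortho to a large group and meta to a chloro group.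

The closest measured change is a step that the two limits leave unreadable from compound 1 to compound 2, where fluoro also replaces hydrogen on an aromatic carbon. The chloro changes give a step that the two limits leave unreadable from compound 1 to compound 3 and a step that the two limits leave unreadable from compound 2 to compound 3. None of these steps has a readable size, so they fix neither the size nor the direction of the new step. Among the compounds with values here, with no compound yet giving a number in this assay, weak inhibition remains the expectation, and the estimate must stay wide. The expected change is an at least 10-fold lower number from compound 3 to compound 4 (1.00 log units; beyond the scatter), an estimate only. For compound 4 the estimated value is 10000 nM, with an expected range of 500 nM to 100000 nM.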

Compound 4, half-maximal inhibitory concentration: 3100 nM
Beside the measured number, compound 4's estimate is 3.2-fold (0.51 log units) above it; low and high end bracket the measured number.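

Compound 4 is the only compound shown that gives a number rather than a limit in this assay, at 3100 nM, while the steps among the three earlier compounds cannot be read. Fluoro in place of hydrogen on an aromatic carbon, ortho to a large group and meta to a chloro group, gives an at least 32-fold lower number from compound 3 to compound 4 (1.50 log units; beyond the scatter), so at this position the change has a readable direction and a large minimum size when the chloro group is present. Read from the other side, chloro in place of hydrogen gives an at least 3.2-fold lower number from compound 2 to compound 4 (0.50 log units; beyond the scatter), and among the compounds shown only the one that carries both fluoro and chloro leaves the limits of the assay.

Both steps give only minimum sizes, and the step from compound 3 stays open-ended because its starting value is a limit of the assay: the limit of > 100000 nM in this assay, at which 2 of the 4 values shown sit. What the compounds shown leave open is how much the fluoro group adds without the chloro group, and whether a methyl group, a methoxy group or a nitrile at the same position would give a number in this assay.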